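The compounds below may be only part of what the source reports. "The series", "measured", "known", "first", "only" and "open" are said of these compounds alone.

Measured compounds:
- compound 1, `Nc1c(C(=O)c2cccc(Br)c2)sc2nc(-c3cccs3)ccc12`: in a functional assay on WI-38 VA13 cells (Homo sapiens) for cytotoxicity (a lower number here means that less compound is needed, a higher number that more compound is needed for the effect), compound 1 gives 0.5 ug/mL.
- compound 2, `Nc1c(C(=O)c2ccc(F)c(F)c2)sc2nc(-c3cccs3)ccc12`: in this assay compound 2 gives only a limit, > 4 ug/mL, not a number.

Compound 2 thus stands at the limit of this assay; of its place on the scale nothing more is known than that, as the line the limit of > 4 ug/mL in this assay, at which 1 of the 2 values shown sits, records. For the measured compounds named here, the one measured step, an at least 8.0-fold higher number from compound 1 to compound 2 (0.90 log units; beyond the scatter), moves from a number to that limit, so its true size is open at the upper end.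

Compound 3, `Nc1c(C(=O)c2ccc(F)cc2F)sc2nc(-c3cccs3)ccc12`, is the next member. It differs from compound 2 by 2,4-difluorophenyl in place of 3,4-difluorophenyl on a carbonyl carbon. Going by the values given here, no measured step compares two difluorophenyl isomers on this carbonyl carbon; the only step in hand, from compound 1 to compound 2, concerns the exchange of a bromine-bearing ring for a difluorophenyl and does not separate the two fluorine patterns. Compound 3 keeps a difluorophenyl, so the step that the limit leaves unreadable from compound 2 to compound 3 is expected to stay within the scatter, with a fair chance that compound 3 again reaches only the limit. The estimate for compound 3 in this assay is 5 ug/mL, in the range 1.5 ug/mL to 20 ug/mL.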

Compound 3, half-maximal effective concentration: 2.3 ug/mL
Compound 3: the middle estimate sits 2.2-fold (0.34 log units) above what was measured; the measured number falls inside the stated range.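

In this assay the exchange of 3,4-difluorophenyl for 2,4-difluorophenyl on the carbonyl carbon gives an at least 1.7-fold lower number from compound 2 to compound 3 (0.24 log units; that floor lies within the scatter) and so shows that a difluorophenyl at this place does not by itself end at a limit. The exchange of the 3-bromophenyl for a difluorophenyl can now be read as a full number, a 4.6-fold higher number from compound 1 to compound 3 (0.66 log units; beyond the scatter) and compound 1 keeps the lowest number of the three, since its steps to both others lie beyond the scatter. Going by these compounds, the true size of the step between the two difluorophenyl isomers stays unknown because compound 2 holds only a limit: the limit of > 4 ug/mL in this assay, at which 1 of the 3 values shown sits.

On these data alone, whether the two fluorine patterns truly differ therefore remains open, and a single pair of isomers could not settle it for other rings in any case. Also open, as far as these compounds go, is whether the lower number of compound 1 belongs to bromine itself or would carry over to a 3-chlorophenyl, a 3-methoxyphenyl or a 4-bromophenyl on this carbonyl carbon.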